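Swapping a Ureido Group for a Sulfonyl Amine

The source may report more compounds than this note shows. Statements on the series, on what has been measured and on what is new or still open speak of the compounds shown alone.

Of the compounds shown here, three sharing one core have been measured in an assay on isolated protein for displacement of a labelled ligand from 5-hydroxytryptamine receptor 6 (Homo sapiens); on this read-out higher numbers stand for weaker inhibition and lower numbers for stronger inhibition. Compound 1 `CN(C)S(=O)(=O)NC[C@@H]1CCCc2cc(S(=O)(=O)c3cccc(F)c3)ccc21` gives 2 nM, compound 2 `O=S(=O)(O)CCCNC[C@@H]1CCCc2cc(S(=O)(=O)c3cccc(F)c3)ccc21` gives 1.26 nM, and compound 3 `NC(=O)NC[C@@H]1CCCc2cc(S(=O)(=O)c3cccc(F)c3)ccc21` gives 0.2 nM. Compound 3 has the lowest number of the three: the step of a 10-fold lower number from compound 1 to compound 3 (1.00 log units; beyond the scatter) and the step of a 6.3-fold lower number from compound 2 to compound 3 (0.80 log units; beyond the scatter) both lie beyond the scatter, while the step of a 1.6-fold lower number from compound 1 to compound 2 (0.20 log units; within the scatter) does not.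

Compound 4 `CN(C[C@@H]1CCCc2cc(S(=O)(=O)c3cccc(F)c3)ccc21)S(C)(=O)=O` has not been measured. It differs from compound 3 by methyl(methylsulfonyl)amino in place of ureido on a saturated chain carbon bound to a saturated ring carbon. The ureido group leaves along with its two hydrogen-bond donors, and a methyl(methylsulfonyl)amino group, carrying no donors, enters on the saturated chain carbon bound to a saturated ring carbon.

Among the compounds with values here, the steps that bear on this change point the same way: moving from the dimethylsulfamoyl or 3-sulfopropyl group to carbamoyl lowered the number in this assay, so going back toward a sulfonyl-bearing group is expected to raise it. The expected step is a 10-fold higher number from compound 3 to compound 4 (1.00 log units; beyond the scatter). Compound 4 is estimated to give 2 nM, with a range from 0.5 nM to 8 nM.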

Compound 4, inhibition constant: 0.398 nM
The estimate for compound 4 lay 5.0-fold (0.70 log units) above the measured number, outside the stated range (below it).
By their numbers in this assay, from the lowest: compounds 3 and 4 (each within the scatter of the next); then compounds 2 and 1 (each within the scatter of the next).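

In this assay, the ureido group is not needed for a low number on this saturated chain carbon bound to a saturated ring carbon: methyl(methylsulfonyl)amino, with 0 hydrogen-bond donors against 2 for ureido, gives a 2.0-fold higher number from compound 3 to compound 4 (0.30 log units; within the scatter). A sulfonyl-bearing group therefore need not raise the number here, and the earlier link between such groups and higher numbers does not hold for this one, as shown by a 5.0-fold lower number from compound 1 to compound 4 (0.70 log units; beyond the scatter) and by a 3.2-fold lower number from compound 2 to compound 4 (0.50 log units; beyond the scatter). No measurement shown here explains these differences.

As far as these compounds go, it remains open whether the methyl on the nitrogen matters, that is, whether methylsulfonylamino, with a hydrogen in its place, would give a similar number. From the compounds shown here alone, how a primary amine or an acetamido group would read at this place is also open.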